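A few compounds are considered here, and "the series" means these few. Any claim that something is new, unique, unknown or untested is made for them only; others in the source may bear on it.

Compound 1 `Oc1ccc(-c2nc3ccccc3s2)cc1O` and compound 2 `COc1ccc(-c2nc3ccccc3s2)cc1OC` share a core, but the difference between the two cores is not broken down here. In a functional assay on MCF7 cells (Homo sapiens) for antiproliferative activity (on this read-out higher numbers stand for weaker inhibition of growth and lower numbers for stronger inhibition of growth), compound 1 gives 2190 nM, while compound 2 gives 52700 nM, the highest number of the three measured compounds. Compound 3 `Oc1ccc(-c2nc3cc(F)ccc3s2)cc1O` is compound 1 with one change, (fluoro in place of hydrogen on an aromatic carbon); in this assay compound 3 gives 720 nM, a step of a 3.0-fold lower number from compound 1 to compound 3 (0.48 log units; beyond the scatter).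

Compound 4 `COc1ccc(-c2nc3ccc(F)cc3s2)cc1OC` has not yet been measured. It stands to compound 2 as compound 3 stands to compound 1, through the same change, (fluoro in place of hydrogen on an aromatic carbon), at a place described in identical words. Among the compounds with values here, the only guide to what this change does is the single step from compound 1 to compound 3, so the expectation for this assay is a step of roughly the same modest size, a 2.6-fold lower number from compound 2 to compound 4 (0.42 log units; beyond the scatter), starting from the much higher number of compound 2. On that basis compound 4 is expected to give about 20000 nM, with a plausible range from 6000 nM to 60000 nM.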

Compound 4, concentration for 50% growth inhibition: 62 nM
Compound 4: middle estimate off by 320-fold (2.51 log units), on the high side, and the stated range ends above it.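

In this assay, fluoro in place of hydrogen gives an 850-fold lower number from compound 2 to compound 4 (2.93 log units; beyond the scatter), so the size of this step did not carry over from one core to the other: the same change on two cores in this assay, a 3.0-fold lower number (0.48 log units; beyond the scatter) from compound 1 to compound 3 and an 850-fold lower number (2.93 log units; beyond the scatter) from compound 2 to compound 4, 280-fold (2.45 log units) apart, beyond the scatter of two such steps.

Both steps run in the same direction, towards a lower number, but two pairs are too few to make that a rule for other cores in the series. They also do not explain the gap, and the shared description of the place, on an aromatic carbon meta to a fused ring and para to a fused ring, does not establish that the fluoro sits on the same carbon in compound 3 and compound 4.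

The compounds shown leave open whether chloro or an amine at that place would give a small step or a large one on each core. They also leave open how a core carrying one hydroxy group and one methoxy group would respond to fluoro.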